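Swapping methoxy for nitro in a growth inhibition series

The compounds below may be only part of what the source reports. "The series", "measured", "known", "first", "only" and "open" are said of these compounds alone.

Three compounds have been measured so far in a functional assay on KB cells (Homo sapiens) for inhibition, read by MTT assay, with a stated time of 24 h, tested at 0.1 ug/mL (a higher number here means more inhibition of growth at the concentration tested, a lower number less inhibition of growth), and are shown here with their results.

compound 1 `O=C(CCCCC(S)CCS)Nc1ccc(Cl)cc1` - 9.11%
compound 2 `O=C(CCCCC(S)CCS)Nc1ccc([N+](=O)[O-])c(C(F)(F)F)c1` - "not active" (no number reported)
compound 3 `COc1ccc(NC(=O)CCCCC(S)CCS)cc1` - "not active" (no number reported)

Compound 3 has no single number. It is recorded as "not active" (no number reported) and shares that kind of entry with compound 2, so compound 1 is the only one of the three with a figure. Compound 4 `O=C(CCCCC(S)CCS)Nc1ccc([N+](=O)[O-])cc1` has yet to be tested. The change that leads to it is nitro in place of methoxy on an aromatic carbon, with nitro taking the place of methoxy on an aromatic carbon, para to a large group.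

For the measured compounds named here, no measured pair in this small set differs in one place, so the size of this step can only be judged loosely. Compound 2 also carries a nitro group and is recorded as "not active" (no number reported), so no shift beyond the usual scatter of this assay is expected, in either direction. A report with no number at all would fit this expectation. If a number is reported, compound 4 is estimated at 5%, with an expected range from 0% to 14%.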

Compound 4, percent growth inhibition at one concentration: "not active" (no number reported)
The entry for compound 4 holds no number; there is nothing to compare the estimate with.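

In this assay, for the compounds shown here, compound 3 and compound 4 are both recorded as not active with no number, so no step between them can be read. The compounds shown leave open whether nitro in place of methoxy shifts growth inhibition at all. No further data shown here bear on this result.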